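Benzyl to aryloxy on the core: acid dissociation expected

A few compounds are considered here, and "the series" means these few. Any claim that something is new, unique, unknown or untested is made for them only; others in the source may bear on it.

In a physicochemical assay for acid dissociation, the three measured compounds stand as follows:
compound 1 `Cc1cc(C)cc(Cc2ccc3c(NCCCNCc4ccco4)ccnc3c2)c1` gives 9.47;
compound 2 `COc1ccc(Oc2ccc3c(NCCCNCc4cc(F)ccc4OC)ccnc3c2)cc1` gives 9.28;
compound 3 `COc1cccc(CNCCCNc2ccnc3cc(Cc4cc(C)cc(C)c4)ccc23)c1O` gives 9.47.

Compound 3 is level with compound 1 at the digits shown, the two together the highest of the three, and compound 2 sits a little lower, within the scatter of compound 3. For the measured compounds named here, the one step that joins two compounds differing in one place, no change at the digits printed from compound 1 to compound 3 (within the scatter), touches the chain amine and not the core. Compound 4 `COc1cccc(CNCCCNc2ccnc3cc(Oc4cccc(N(C)C)c4)ccc23)c1O` differs from compound 3 by 3-(dimethylamino)phenoxy in place of 3,5-dimethylbenzyl on an aromatic carbon. Going by the values given here, no measured step covers this change; compound 2, which carries an aryloxy group on its core, shows a number close to compound 3. A step of a number 0.12 log units lower from compound 3 to compound 4 (within the scatter) is therefore expected, none beyond the scatter. Compound 4 is estimated at 9.35, within 9 to 9.7.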

Compound 4, acid dissociation constant: 9.28
For compound 4 the middle estimate is 0.07 log units above the measured one, within the range that was stated.
By their numbers in this assay, from the lowest: compounds 2, 4, 1 and 3 (each within the scatter of the next).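

The step on the core, 3-(dimethylamino)phenoxy in place of 3,5-dimethylbenzyl, reads a number 0.19 log units lower from compound 3 to compound 4 (within the scatter) in this assay. The earlier step touched only the chain amine, whereas this one shows that at this aromatic carbon, a group with 2 hydrogen-bond acceptors can replace one with 0 without a move beyond the scatter. No evidence is available that bears on this result. The compounds shown leave open whether a carboxylic acid or a primary amine on this aromatic carbon would also stay within the scatter in this assay.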